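A few compounds are considered here, and "the series" means these few. Any claim that something is new, unique, unknown or untested is made for them only; others in the source may bear on it.

Measured compounds in the series:

Compound 1, `O=C1C(NC2CCCC2)=CC(=O)c2c1nc1n2[C@H]2OC[C@@H](O)[C@H]2OC1`: in a functional assay on HeLa cells (Homo sapiens) for inhibition, read by sulforhodamine B assay (on this read-out lower numbers stand for stronger inhibition and higher numbers for weaker inhibition), compound 1 gives > 16000 nM, which is a limit of the assay rather than a number.
Compound 2, `COc1ccccc1NC1=CC(=O)c2c(nc3n2[C@H]2OC[C@@H](O)[C@H]2OC3)C1=O`: in this assay compound 2 gives 7460 nM.
Compound 3, `O=C1C=C(NC2CCCC2)C(=O)c2c1nc1n2[C@H]2OC[C@@H](O)[C@H]2OC1`: in this assay compound 3 gives > 16000 nM, again a limit of the assay and not a number.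

Within the data shown here, the one change that is followed by a measured pair is 2-methoxyphenyl in place of cyclopentyl on an amine nitrogen. It gives an at least 2.1-fold lower number from compound 1 to compound 2 (0.33 log units; beyond the scatter). The size of this step is known only as a bound, because compound 1 sits at the limit of > 16000 nM in this assay, at which 2 of the 3 values shown sit. Compound 3 carries the same atoms as compound 1, joined differently; the difference between the two cores is not broken down here. Compound 3 likewise sits at a limit, so its value and that of compound 1 cannot be put in order.

Compound 4, `COc1ccccc1NC1=CC(=O)c2nc3n(c2C1=O)[C@H]1OC[C@@H](O)[C@H]1OC3`, has not yet been measured in this assay. It stands to compound 3 as compound 2 stands to compound 1: 2-methoxyphenyl in place of cyclopentyl on an amine nitrogen. The place is described in the same words for both pairs, so this is the same change, not merely the same kind. On the core of compound 3 the step is expected to be an at least 1.7-fold lower number from compound 3 to compound 4 (0.24 log units; that floor lies within the scatter), in line with the bound set by an at least 2.1-fold lower number from compound 1 to compound 2 (0.33 log units; beyond the scatter) on the core of compound 1. As far as these compounds go, whether the second core carries the change equally well is unknown, and the estimate is correspondingly wide. Compound 4 is estimated at 9000 nM, between 3000 nM and 30000 nM.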

Compound 4, half-maximal inhibitory concentration: 2950 nM
Beside the measured number, compound 4's estimate is 3.1-fold (0.48 log units) above it, outside the stated range (below it).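

In this assay, moving from cyclopentylamino to (2-methoxyphenyl)amino on the core of compound 3 gives an at least 5.4-fold lower number from compound 3 to compound 4 (0.73 log units; beyond the scatter), so the lower number seen on the core of compound 1 recurs on this second core. Set side by side, the two steps read: the same change on two cores in this assay, an at least 2.1-fold lower number (0.33 log units; beyond the scatter) from compound 1 to compound 2 and an at least 5.4-fold lower number (0.73 log units; beyond the scatter) from compound 3 to compound 4; the limit leaves it open whether they differ. The direction therefore carries across these two cores, but this is one change on two cores and no general rule for the series, and neither step has a known size, with the starting compound of each pair sitting at a limit of the assay rather than at a number: the limit of > 16000 nM in this assay, at which 2 of the 4 values shown sit.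

The compounds shown leave open how much of the step belongs to the aromatic ring and how much to the methoxy group, a question that an unsubstituted phenyl on the same amine nitrogen would address on both cores. Also open, as far as these compounds go, is how either core would respond to a quite different group on that nitrogen, such as a longer chain ending in a tertiary amine or a carboxylic acid.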